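The source may hold more compounds than are shown below. What is called first, only, known or untested is meant among the compounds shown, and "the series" means these compounds.

Of the compounds shown here, three of one family have been measured in an assay on cells (1-87 tumor cell line) for inhibition of Polyunsaturated fatty acid 5-lipoxygenase (Homo sapiens), with a stated time of 5 min; a higher number here means a weaker inhibitor, a lower number a stronger inhibitor. Compound 1 `CC(=O)CC1CC(=O)N(c2ccccc2)C1=O` gives 62400 nM, and compound 3 `O=C1CCCCC1C1CC(=O)N(Cc2ccccc2)C1=O` gives 36000 nM. Compound 2 `NS(=O)(=O)c1ccc(N2C(=O)CC(CC(=O)c3ccccc3)C2=O)cc1` gives 5290 nM and so has the lowest number of the three, making it the strongest inhibitor seen so far: its gaps to compound 3 and to compound 1 both lie beyond the usual scatter of repeated measurements.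

Compound 4 `NS(=O)(=O)c1ccc(N2C(=O)CC(CC(=O)c3ccc(Cl)cc3)C2=O)cc1` has not yet been measured. It differs from compound 2 in one place: chloro in place of hydrogen on an aromatic carbon. The chloro group sits on an aromatic carbon of the benzoyl ring, so the benzoyl becomes a (4-chlorophenyl)carbonyl while everything else stays as in compound 2.

Going by the values given here, no pair of measured compounds differs in just one place, so there is no measured step to lean on. A single chloro added to a phenyl ring usually shifts numbers only modestly, and the direction is open. For compound 4 the expected step is a 1.5-fold lower number from compound 2 to compound 4 (0.18 log units; within the scatter), a small change that may not exceed the scatter. Compound 4 is therefore estimated at 3500 nM, with a likely range from 1200 nM to 10000 nM.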

Compound 4, half-maximal inhibitory concentration: 12600 nM
For compound 4 the middle estimate is 3.6-fold (0.56 log units) below the measured one; measured number above the stated range.
By their numbers in this assay, from the lowest: compound 2; then compound 4; then compounds 3 and 1 (each within the scatter of the next).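

Putting chloro in place of hydrogen on the benzoyl ring, para to a large group, gives a 2.4-fold higher number from compound 2 to compound 4 (0.38 log units; beyond the scatter) in this assay. Going by these compounds alone, this is the first measured change in this family that touches one place only, and it shows that this ring position is not indifferent to substitution: a single added chlorine atom yields a modestly weaker inhibitor. Nothing among the available data explains why the number rises.

The compounds shown leave open whether this loss belongs to chloro itself or would appear with any group at this place, such as fluoro, methoxy or an amine. They also leave open whether chloro elsewhere on the same ring would give a similar step, or whether a group at this place could give a lower number than hydrogen does.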